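This account rests on a few compounds, and the source may have more. Where it says the series, first, only, none or still open, it means among the compounds named here.

Series notes. For the measured compounds named here, in an ADME assay on HEK293 cells (Homo sapiens) for cytotoxicity, read by MTT assay, with a stated time of 48 h (on this read-out lower numbers stand for stronger inhibition and higher numbers for weaker inhibition), compound 2 `COc1cc(NC(=O)c2cc(C(F)(F)F)cc(C(F)(F)F)c2)ccc1NS(C)(=O)=O` gives 42000 nM, the only actual number in the set. For compound 1 `COc1cc(NC(=O)c2cccc(C(F)(F)F)c2)ccc1NS(C)(=O)=O` the reading is a limit, > 250000 nM. For compound 3 `COc1cc(NC(=O)c2cc(C(F)(F)F)cc(C(F)(F)F)c2)ccc1NS(=O)(=O)C(F)(F)F` the reading is likewise a limit, > 250000 nM. The measured steps are an at least 5.9-fold lower number from compound 1 to compound 2 (0.77 log units; beyond the scatter) and an at least 5.9-fold higher number from compound 2 to compound 3 (0.77 log units; beyond the scatter); each runs between compound 2 and a limit, so each gives only a lower bound on its size.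

Compound 4 `CS(=O)(=O)Nc1ccc(NC(=O)c2cc(C(F)(F)F)cc(C(F)(F)F)c2)cc1F` differs from compound 2 by fluoro in place of methoxy on an aromatic carbon. Neither measured step matches this exchange: one puts trifluoromethyl in place of hydrogen on an aromatic carbon, the other puts trifluoromethyl in place of methyl on a sulfonyl sulfur, and both move the number by modest amounts beyond the scatter. Going by the values given here, the change to compound 4 is smaller in the count of atoms than either, and no closer precedent exists in the set. The expectation is therefore a 1.8-fold higher number from compound 2 to compound 4 (0.25 log units; within the scatter) in this assay, with the number, if anything, drifting higher rather than lower. Compound 4 is estimated at 75000 nM, with a range from 25000 nM to 250000 nM. A reading that is only a limit is a real possibility for compound 4, given (the limit of > 250000 nM in this assay, at which 2 of the 3 values shown sit).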

Compound 4, half-maximal inhibitory concentration: > 250000 nM
Compound 4 ended at the assay's limit; the forecaster's own chance of this, stated with the estimate: 40%; at least 3.3-fold (0.52 log units) between middle value and limit.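

In this assay, fluoro in place of methoxy on the aromatic carbon ortho to a methanesulfonamido group gives an at least 5.9-fold higher number from compound 2 to compound 4 (0.77 log units; beyond the scatter), so this position, which neither earlier step touched, also bears on the read-out. With this result, each of the three single changes shown away from compound 2 ends at a limit, whether on the benzoyl side, on the sulfonyl sulfur or at this ring carbon, and compound 2 remains the only compound in the set with an actual number. The reading for compound 4 is itself a limit, so the step sets only a lower bound on the effect of this exchange, and the reading sits where most of the set now sits: the limit of > 250000 nM in this assay, at which 3 of the 4 values shown sit.

What stays open is whether methoxy is specifically needed at this carbon or whether fluoro alone moves the number, since only one replacement is shown there. An ethoxy, a hydroxyl, a chlorine or plain hydrogen on the same carbon, with the rest of compound 2 unchanged, would separate these readings and show whether any of them stays clear of the limit.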